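This account rests on a few compounds, and the source may have more. Where it says the series, first, only, none or still open, it means among the compounds named here.

Measured compounds:
compound 1 `COc1cc2c(Oc3ccc(NC(=O)c4cn(-c5ccccc5)nn4)cc3F)ccnc2cc1OCCCN1CCCC1` gives 360 nM in a functional assay on A549 cells (Homo sapiens) for cytotoxicity, read by MTT assay, with a stated time of 72 h; a lower number here means a stronger inhibitor, a higher number a weaker inhibitor
compound 2 `COc1cc2c(Oc3ccc(NC(=O)c4cn(-c5ccccc5C)nn4)cc3F)ccnc2cc1OCCCN1CCCC1` gives 900 nM
compound 3 `COc1cc2c(Oc3ccc(NC(=O)c4cn(-c5c(C)cccc5C)nn4)cc3F)ccnc2cc1OCCCN1CCCC1` gives 1240 nM

Compound 2 stands second highest of the three numbers: a 2.5-fold higher number from compound 1 to compound 2 (0.40 log units; beyond the scatter), whereas a 1.4-fold higher number from compound 2 to compound 3 (0.14 log units; within the scatter). Compound 4 `COc1cc2c(Oc3ccc(NC(=O)c4cn(-c5ccccc5C)nn4)cc3F)ccnc2cc1OCCCN1CCC(C)CC1` differs from compound 2 by 4-methylpiperidin-1-yl in place of pyrrolidin-1-yl on a saturated chain carbon, three bonds along the chain from an oxygen on an aromatic ring.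

All three measured steps concern the phenyl on the aromatic nitrogen, not the 3-(pyrrolidin-1-yl)propyl end of the molecule: a 2.5-fold higher number from compound 1 to compound 2 (0.40 log units; beyond the scatter), a 3.4-fold higher number from compound 1 to compound 3 (0.54 log units; beyond the scatter) and a 1.4-fold higher number from compound 2 to compound 3 (0.14 log units; within the scatter). Within the data shown here, none of them bears on an exchange of the saturated amine ring, so there is no measured precedent for the step to compound 4 within this series, and the working assumption is that this assay shows no step beyond the scatter. Compound 4 is therefore estimated at 900 nM, with a range of 350 nM to 2300 nM. For compound 4 this means an expected no change at the digits printed from compound 2 to compound 4 (within the scatter), with the range kept wide since nothing measured constrains it.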

Compound 4, half-maximal inhibitory concentration: 3500 nM
Estimate against measurement, compound 4: 3.9-fold (0.59 log units) below; measured number above the stated range.
By their numbers in this assay, from the lowest: compound 1; then compounds 2 and 3 (each within the scatter of the next); then compound 4.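

In this assay, the 3-(pyrrolidin-1-yl)propyl end of the molecule proves to be a second place where the number moves: 4-methylpiperidin-1-yl in place of pyrrolidin-1-yl gives a 3.9-fold higher number from compound 2 to compound 4 (0.59 log units; beyond the scatter). This step, beyond the scatter, is of the same modest order as the change on the phenyl on the aromatic nitrogen, a 3.4-fold higher number from compound 1 to compound 3 (0.54 log units; beyond the scatter), so that phenyl is no longer the only place shown to matter. Nothing at hand bears on what lies behind the step.

Among these compounds, the single exchange joins a five-membered to six-membered ring change with an added methyl, so it remains open whether plain piperidin-1-yl would follow pyrrolidin-1-yl or 4-methylpiperidin-1-yl. Also open, going by these compounds, are how morpholin-4-yl or a dimethylamino group would read at this place, and whether the step holds with the unsubstituted phenyl of compound 1.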